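Thioether series: methoxy in place of fluoro

The source may hold more compounds than are shown below. What is called first, only, known or untested is meant among the compounds shown, and "the series" means these compounds.

Compound 1 `Nc1cc(N)c2nc(-c3ccccc3)c(Sc3ccc(F)cc3)nc2c1` carries a (4-fluorophenyl)sulfanyl group on the shared core. In a functional assay on IGROV-1 cells (Homo sapiens) for inhibition, read by sulforhodamine B assay, with a stated time of 48 h (on this read-out lower numbers stand for stronger inhibition of growth and higher numbers for weaker inhibition of growth), compound 1 gives only a limit, < 100000 nM. That limit is the one recorded as the limit of < 100000 nM in this assay, at which 1 of the 3 values shown sits. Compound 2 `COc1cc(CNc2nc3cc(N)cc(N)c3nc2-c2ccccc2)cc(OC)c1OC` in this assay likewise gives only a limit, < 50200 nM. It sits at the limit of < 50200 nM in this assay, at which 1 of the 3 values shown sits. Compound 3 `COc1ccc(CNc2nc3cc(N)cc(N)c3nc2-c2ccccc2)cc1OC` in this assay gives 40700 nM. Going by the values given here, the one measured step within the set, a step that the limit leaves unreadable from compound 2 to compound 3, cannot be read for size, so no single change in this set has a readable effect on growth inhibition.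

Compound 4 `COc1ccc(Sc2nc3cc(N)cc(N)c3nc2-c2ccccc2)cc1` differs from compound 1 by methoxy in place of fluoro on an aromatic carbon. Among the compounds with values here, no measured step bears directly on this change: the change between compound 2 and compound 3 also concerns a methoxy on an aromatic carbon, but its size is hidden by the limit of compound 2. Compound 1 itself stands at a limit in this assay, so the step to compound 4 has no readable starting number either. Within the data shown here, compound 3 gives the only full number in the set, and compound 4 is expected near it. The step from compound 1 to compound 4 is expected as a step that the limit leaves unreadable from compound 1 to compound 4, with no direction beyond the scatter claimed. Compound 4 is estimated at 40000 nM, within 12000 nM to 100000 nM.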

Compound 4, concentration for total growth inhibition: < 100000 nM
Compound 4 ended at the assay's limit; the forecaster's own chance of this, stated with the estimate: 40%; the middle value does not contradict the limit.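

In this assay compound 4 gives only a limit and compound 1 likewise, so no size can be read for the change between compound 1 and compound 4: the limit of < 100000 nM in this assay, at which 2 of the 4 values shown sit. The compounds shown leave open whether methoxy in place of fluoro changes growth inhibition at all, and in which direction.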